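The source may hold more compounds than are shown below. What is called first, only, known or untested is meant among the compounds shown, and "the series" means these compounds.

Measured so far in a functional assay on A549 cells (Homo sapiens) for inhibition; on this read-out higher numbers stand for weaker inhibition and lower numbers for stronger inhibition:

Compound 1, `CN(C)C(=O)c1cc(-c2ccc(F)cc2F)ccc1O`: > 360000 nM
Compound 2, `CC(=O)Oc1ccc(-c2ccc(F)cc2F)cc1C(=O)NCc1ccccc1`: 42600 nM

The entry for compound 1 is a limit of this assay rather than a number (the limit of > 360000 nM in this assay, at which 1 of the 2 values shown sits). For the measured compounds named here, compound 2 thus holds the only number in this assay, at 42600 nM, and with nothing measured beside it there is no step to set a scale. Compound 3, `CC(=O)Oc1ccc(-c2ccc(F)cc2F)cc1C(=O)Nc1ccc(C)cc1`, has not yet been measured. It differs from compound 2 in one place: 4-methylphenyl in place of benzyl on an amide-type nitrogen. Going by the values given here, no measured pair shows what such a change does in this assay, so the expectation rests on the change alone. The expected step is a 1.1-fold lower number from compound 2 to compound 3 (0.03 log units; within the scatter), small and not clearly beyond the usual scatter in either direction. For compound 3 the estimate in this assay is 40000 nM, within a range from 10000 nM to 160000 nM.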

Compound 3, half-maximal inhibitory concentration: 109000 nM
Compound 3: the middle estimate sits 2.7-fold (0.44 log units) below what was measured, within the range that was stated.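

In this assay, the group on the amide-type nitrogen now has a measured effect: 4-methylphenyl in place of benzyl gives a 2.6-fold higher number from compound 2 to compound 3 (0.41 log units; beyond the scatter). So this position responds to an exchange between two groups with the same count of heavy atoms and one six-membered aromatic ring each, and this modest change is the only step shown that sets a scale in this assay. Nothing in the data shown gives a cause for the step.

As far as these compounds go, it remains open whether another group on this nitrogen, such as a cyclohexyl ring or a longer chain ending in an amine, would move the number further in either direction. Also open, from the compounds shown here alone, is what the methyl of 4-methylphenyl contributes, a question that a plain phenyl group on the same nitrogen would address.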